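From 4-bromophenyl to 4-methoxyphenyl: working notes

The source may report more compounds than this note shows. Statements on the series, on what has been measured and on what is new or still open speak of the compounds shown alone.

In a functional assay on A549 cells (Homo sapiens) for inhibition, read by MTT assay, with a stated time of 72 h (on this read-out higher numbers stand for weaker inhibition and lower numbers for stronger inhibition), compound 1 (`Cc1ccccc1-c1cc(C(=O)N2CCC3(CC2)CC(=O)c2nn(C(C)(C)C)cc2O3)c2ccccc2n1`) gives 1880 nM, compound 2 (`CC(C)(C)n1cc2c(n1)C(=O)CC1(CCN(C(=O)c3cc(-c4ccc(Cl)cc4)nc4ccccc34)CC1)O2`) gives 2330 nM and compound 3 (`CC(C)(C)n1cc2c(n1)C(=O)CC1(CCN(C(=O)c3cc(-c4ccc(Br)cc4)nc4ccccc34)CC1)O2`) gives 9300 nM. Of these three, compound 3 has the highest number and so the weakest inhibition. The next structure, compound 4 (`COc1ccc(-c2cc(C(=O)N3CCC4(CC3)CC(=O)c3nn(C(C)(C)C)cc3O4)c3ccccc3n2)cc1`), has methoxy in place of bromo on an aromatic carbon, para to a large group: methoxy in place of bromo on an aromatic carbon.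

Within the data shown here, no methoxy compound has been measured, so only indirect evidence bears on this change. The closest step is the modest 4.0-fold higher number from compound 2 to compound 3 (0.60 log units; beyond the scatter), where bromo replaces chloro. The step of a 4.9-fold higher number from compound 1 to compound 3 (0.69 log units; beyond the scatter) is of similar size, whereas a 1.2-fold higher number from compound 1 to compound 2 (0.09 log units; within the scatter) stays within the scatter. Among these three compounds, only the bromo compound stands apart, so a modest move to a lower number is expected in this assay, though three compounds make thin support. The expected change is a 2.4-fold lower number from compound 3 to compound 4 (0.39 log units; beyond the scatter). The estimate for compound 4 is 3800 nM, with an expected range of 1300 nM to 10000 nM.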

Compound 4, half-maximal inhibitory concentration: 3740 nM
Beside the measured number, compound 4's estimate is 1.0-fold (0.01 log units) above it; measured number inside the range.
By their numbers in this assay, from the lowest: compounds 1, 2 and 4 (each within the scatter of the next); then compound 3.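

In this assay the step of a 2.5-fold lower number from compound 3 to compound 4 (0.40 log units; beyond the scatter) is modest, and it shows that the number at this place para to a large group does not stay at the level of compound 3 when methoxy, with its one hydrogen-bond acceptor, replaces bromo. The steps of a 1.6-fold higher number from compound 2 to compound 4 (0.21 log units; within the scatter) and a 2.0-fold higher number from compound 1 to compound 4 (0.30 log units; within the scatter) both lie within the scatter, so compound 4 groups with compounds 1 and 2, leaving compound 3 alone as the one apart among the four. No measurement shown accounts for the gap between bromo and the other groups.

On these data alone, whether iodo or fluoro at this place would follow bromo or chloro remains open. So does the place of a dimethylamino group or a carboxylic acid in this ordering.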